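Ring-closed ester tail on a dihydropyridine vasorelaxant

The source may report more compounds than this note shows. Statements on the series, on what has been measured and on what is new or still open speak of the compounds shown alone.

Compound 1 `CO/C(O)=C1\C(C)=NC(C)=C(C(=O)OCCCN2C(=O)c3ccccc3S2(=O)=O)C1c1ccccc1[N+](=O)[O-]`: 1.5 nM
Compound 2 `COCCO/C(O)=C1\C(C)=NC(C)=C(C(=O)OCCCN2C(=O)c3ccccc3S2(=O)=O)C1c1ccccc1[N+](=O)[O-]`: 2.7 nM

Both compounds were tested in a functional assay (aorta) with Oryctolagus cuniculus as the target; on this read-out higher numbers stand for weaker inhibition and lower numbers for stronger inhibition. Compound 2 has the highest of the two numbers; its nearest neighbour is compound 1, and the step of a 1.8-fold higher number from compound 1 to compound 2 (0.26 log units; within the scatter) lies within the scatter, so the two values cannot be told apart.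

Compound 3 `CC1=NC(C)=C(C(=O)OCCCN2C(=O)c3ccccc3S2(=O)=O)C(c2ccccc2[N+](=O)[O-])/C1=C(\O)OCC1CCCCO1` differs from compound 2 in one place: oxan-2-yl in place of methoxymethyl on a saturated chain carbon bound to an oxygen on an unsaturated carbon. For the measured compounds named here, the only measured step that bears on this region is a 1.8-fold higher number from compound 1 to compound 2 (0.26 log units; within the scatter), which added a small open chain without moving the number beyond the scatter. The new change is larger and closes the chain into a ring, but nothing measured shows how a ring at this place behaves. A step of a 1.3-fold higher number from compound 2 to compound 3 (0.11 log units; within the scatter) in this assay is therefore expected, small and possibly upward. Compound 3 is estimated at 3.5 nM, within a range of 1.2 nM to 10 nM.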

Compound 3, half-maximal inhibitory concentration: 11.5 nM
Estimate against measurement, compound 3: 3.3-fold (0.52 log units) below; measured number above the stated range.
By their numbers in this assay, from the lowest: compounds 1 and 2 (each within the scatter of the next); then compound 3.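

In this assay, this position, a saturated chain carbon bound to an oxygen on an unsaturated carbon, does not tolerate every addition equally: oxan-2-yl in place of methoxymethyl brings a 4.3-fold higher number from compound 2 to compound 3 (0.63 log units; beyond the scatter), whereas the small open chain of compound 2 could not be told apart from compound 1. Taken from the plain hydrogen, the change to oxan-2-yl amounts to a 7.7-fold higher number from compound 1 to compound 3 (0.88 log units; beyond the scatter), so among these three compounds only the ring-bearing group goes with clearly weaker inhibition. The data at hand offer no explanation for this step.

Still open, going by these compounds, is whether the closed ring or simply the larger group matters, a question that a longer open chain of ether type or a cyclohexyl group could address. On these data alone, how a basic amine at the end of this chain would behave also remains unknown.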